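The compounds below may be only part of what the source reports. "The series", "measured", "known", "first", "only" and "open" are said of these compounds alone.

Measured in a physicochemical assay for lipophilicity, measured as octanol-water partition; on this read-out higher numbers stand for higher lipophilicity and lower numbers for lower lipophilicity:
- compound 1 `COC(=O)c1ccc(/C=C/C(=O)N[C@@H]2O[C@H](CO)[C@@H](O)[C@H](O)[C@H]2O)cc1`: -0.805
- compound 2 `COc1ccc(/C=C/C(=O)N[C@@H]2O[C@H](CO)[C@@H](O)[C@H](O)[C@H]2O)c(O)c1`: -0.958
- compound 3 `CC[C@H](CC(=O)N[C@@H]1O[C@H](CO)[C@@H](O)[C@H](O)[C@H]1O)c1ccc(C)c(C)c1`: 0.01

Compound 1 lies within the usual scatter of compound 2, so these two cannot be told apart, while compound 3 stands clearly higher than both. Compound 4 `CC(C)c1ccc(/C=C/C(=O)N[C@@H]2O[C@H](CO)[C@@H](O)[C@H](O)[C@H]2O)cc1` has isopropyl in place of methoxycarbonyl on an aromatic carbon, para to a large group (isopropyl in place of methoxycarbonyl on an aromatic carbon). Going by the values given here, no measured pair isolates this swap, so the expectation is a rough one. It rests on the all-carbon entering group and on compound 3, with only carbon groups on its aromatic ring, at 0.01. The expected step is a number 1.01 log units higher from compound 1 to compound 4 (beyond the scatter), upward in this assay and beyond the scatter. For compound 4 the estimated value is 0.2, with an expected range of -0.3 to 0.7.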

Compound 4, partition coefficient: 0.296
Compound 4: middle estimate off by 0.10 log units, on the low side, and the stated range covers the measured number.
By their numbers in this assay, from the lowest: compounds 2 and 1 (each within the scatter of the next); then compounds 3 and 4 (each within the scatter of the next).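

In this assay, going by these compounds alone, the change of isopropyl in place of methoxycarbonyl on an aromatic carbon, para to a large group, gives a number 1.10 log units higher from compound 1 to compound 4 (beyond the scatter) and is the first comparison here that isolates a single place. A swap at this one position, with the rest of the molecule unchanged, is therefore enough to produce a large step. Nothing measured here explains the size of this step.

A single swap cannot separate the loss of the two oxygens from the arrival of the all-carbon group. Going by these compounds, how an amine, a carboxylic acid or a longer chain would compare at this position remains open.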